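The source may report more compounds than this note shows. Statements on the series, on what has been measured and on what is new or still open speak of the compounds shown alone.

Measured so far in a functional assay on HeLa cells (Homo sapiens) for cytotoxicity, read by ELISA, with a stated time of 2 days; on this read-out higher numbers stand for weaker inhibition and lower numbers for stronger inhibition:

compound 1, `Oc1cccc(-c2cc(-c3ccccc3)cc(-c3ccco3)n2)c1`, compound 1 gives 9430 nM
compound 2, `Oc1cccc(-c2cc(-c3ccccc3)cc(-c3ccncc3)n2)c1`, compound 2 gives 28100 nM
compound 3, `Oc1ccc(-c2cc(-c3ccccc3)nc(-c3ccco3)c2)cc1`, compound 3 gives 4500 nM

Compound 3 holds the lowest of the three numbers; its steps to compound 1 and to compound 2 are both beyond the scatter. Compound 1 and compound 3 are built from the same atoms joined differently; the difference between the two cores is not broken down here.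

One change is seen once as a measured step and is now to be made a second time. From compound 1 to compound 2 the change is pyridin-4-yl in place of furan-2-yl on an aromatic carbon, and it brought a 3.0-fold higher number from compound 1 to compound 2 (0.47 log units; beyond the scatter). From compound 3 to compound 4, `Oc1ccc(-c2cc(-c3ccccc3)nc(-c3ccncc3)c2)cc1`, the change is pyridin-4-yl in place of furan-2-yl on an aromatic carbon. Around the place the two differ only in that the site in compound 1 is meta to a 3-hydroxyphenyl group, whereas in compound 3 it is meta to a 4-hydroxyphenyl group; the change is therefore the same kind of change, not the same.

With a single earlier instance to rest on, the step from compound 3 to compound 4 in this assay is expected to be of similar size, a 3.0-fold higher number from compound 3 to compound 4 (0.48 log units; beyond the scatter), because compound 2 stood at a 3.0-fold higher number from compound 1 to compound 2 (0.47 log units; beyond the scatter). Compound 4 is thus estimated at 13500 nM, with a range from 6000 nM to 30000 nM.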

Compound 4, half-maximal inhibitory concentration: 1600 nM
For compound 4 the middle estimate is 8.4-fold (0.93 log units) above the measured one; measured number outside the range, below it.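

In this assay, pyridin-4-yl in place of furan-2-yl on the core of compound 3 brings a 2.8-fold lower number from compound 3 to compound 4 (0.45 log units; beyond the scatter). Set beside the earlier step, the same change moves the number in opposite directions on the two cores, so the step seen on one core gives no usable estimate of either size or direction on the other: the same change on two cores in this assay, a 3.0-fold higher number (0.47 log units; beyond the scatter) from compound 1 to compound 2 and a 2.8-fold lower number (0.45 log units; beyond the scatter) from compound 3 to compound 4, 8.4-fold (0.92 log units) apart, beyond the scatter of two such steps This rests on only two matched pairs and shows that the step depends on the core in these compounds, but it does not show which difference between the cores is responsible, whether the 3-hydroxyphenyl or 4-hydroxyphenyl group or the way the core atoms are joined, nor does it give a rule for any other core in the series.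

The compounds shown leave open whether another group at this site, such as thiophen-2-yl or pyridin-3-yl, would also move in opposite directions on the two cores. Also open, from the compounds shown here alone, is how the comparison would run with a methoxy group or an amine in place of the hydroxy group on either core.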